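Replacing naphthalen-2-yl on the oxygen: towards compound 4

The compounds below may be only part of what the source reports. "The series", "measured", "known", "first", "only" and "open" are said of these compounds alone.

Measured so far in a functional assay on Jurkat cells (Homo sapiens); a lower number here means a stronger inhibitor, a higher number a weaker inhibitor:
Compound 1 `CC(C)[C@H](NC(=O)COc1cccc2ccccc12)C(=O)N[C@@H](CC(=O)O)C(=O)COc1ccc2ccccc2c1` gives > 100000 nM, which is a limit of the assay and not a number.
Compound 2 `CC(C)[C@H](NC(=O)COc1cccc2ccccc12)C(=O)N[C@@H](CC(=O)O)C(=O)COc1ccc(-c2ccccc2)cc1` gives 87900 nM.
Compound 3 `CC(C)[C@H](NC(=O)COc1cccc2ccccc12)C(=O)N[C@@H](CC(=O)O)C(=O)COc1ccc([N+](=O)[O-])cc1` gives > 100000 nM, again a limit of the assay rather than a number.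

Compound 1 therefore stands at the edge of what this assay reports, and it does not stand alone there (the limit of > 100000 nM in this assay, at which 2 of the 3 values shown sit). The two steps taken from it are small or unreadable: an at least 1.1-fold lower number from compound 1 to compound 2 (0.05 log units; that floor lies within the scatter), and a step that the two limits leave unreadable from compound 1 to compound 3. Neither gives a readable change beyond the scatter on exchanging the group on the oxygen on the saturated carbon.

Compound 4 `CC(C)[C@H](NC(=O)COc1cccc2ccccc12)C(=O)N[C@@H](CC(=O)O)C(=O)COc1ccc(F)cc1F` carries the change (2,4-difluorophenyl in place of naphthalen-2-yl on an oxygen on a saturated carbon). The steps from compound 1 to compound 2 and from compound 1 to compound 3 are the ones that bear on it, and both leave the number near or at the limit, so no step beyond the scatter is expected from compound 1 to compound 4, with a limit again the most likely outcome. Compound 4 is expected at 100000 nM, between 40000 nM and 300000 nM. That expectation amounts to a number no higher from compound 1 to compound 4 (the limit leaves the size open).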

Compound 4, half-maximal inhibitory concentration: 33200 nM
Estimate against measurement, compound 4: 3.0-fold (0.48 log units) above; measured number outside the range, below it.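

In this assay, the group on the oxygen on the saturated carbon now produces readable steps: an at least 3.0-fold lower number from compound 1 to compound 4 (0.47 log units; beyond the scatter) and an at least 3.0-fold lower number from compound 3 to compound 4 (0.47 log units; beyond the scatter). The step with a number at both ends is a 2.6-fold lower number from compound 2 to compound 4 (0.42 log units; beyond the scatter), so 2,4-difluorophenyl ranks ahead of both 4-phenylphenyl and naphthalen-2-yl at this position, though ring count alone does not explain the order, as compound 3 with 4-nitrophenyl goes against that reading. The first two steps are floors only, since compound 1 and compound 3 remain limits of the assay: the limit of > 100000 nM in this assay, at which 2 of the 4 values shown sit.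

As far as these compounds go, it remains open whether both fluorines are needed, which 4-fluorophenyl or plain phenyl on the same oxygen would address. From the compounds shown here alone, it is also open whether an aromatic ring is required at all, which cyclohexyl there would test.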